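The source may report more compounds than this note shows. Statements on the series, on what has been measured and on what is new or still open speak of the compounds shown alone.

Measured in a functional assay on SNB-19 cells (Homo sapiens) for inhibition, read by sulforhodamine B assay, with a stated time of 48 h; a lower number here means a stronger inhibitor of growth, a higher number a weaker inhibitor of growth:

Compound 1 `COc1cc(-c2cc(/C=C/C(=O)c3ccc(Cl)c(Cl)c3)[nH]n2)cc(OC)c1OC`: > 100000 nM, a limit of the assay.
Compound 2 `COc1ccc(C(=O)/C=C/c2cc(-c3cc(OC)c(OC)c(OC)c3)n[nH]2)cc1OC`: 3010 nM.

Going by the values given here, compound 2 holds the only true number so far, as the one other result is a limit. Compound 3 `COc1cc(-c2cc(/C=C/C(=O)c3ccc(F)c(F)c3)[nH]n2)cc(OC)c1OC` has 3,4-difluorophenyl in place of 3,4-dimethoxyphenyl on a carbonyl carbon. Among the compounds with values here, one measured step bears on this change: an at least 33-fold lower number from compound 1 to compound 2 (1.52 log units; beyond the scatter), a large step that brought in 3,4-dimethoxyphenyl in place of 3,4-dichlorophenyl. Removing that group again suggests a partial reversal in this assay, towards a higher number. The expected change is an 8.3-fold higher number from compound 2 to compound 3 (0.92 log units; beyond the scatter). For compound 3 the estimated value is 25000 nM, with an expected range of 4000 nM to 100000 nM.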

Compound 3, concentration for total growth inhibition: > 100000 nM
Compound 3 was reported as a limit; the forecaster's own chance of this, stated with the estimate: 35%; middle value at least 4.0-fold (0.60 log units) from the limit.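

Placing 3,4-difluorophenyl on the carbonyl carbon in place of 3,4-dimethoxyphenyl brings an at least 33-fold higher number from compound 2 to compound 3 (1.52 log units; beyond the scatter) in this assay. So a second replacement of 3,4-dimethoxyphenyl on this carbon, with different atoms from the first, also loses the measurable growth inhibition. The step between compound 1 and compound 3 cannot be read, and compound 2 alone keeps a true number: the limit of > 100000 nM in this assay, at which 2 of the 3 values shown sit.

On these data alone, whether the two methoxy groups are both needed remains open. So does whether a ring carrying a single methoxy group, or an amine, would give a readable value.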